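Ring opened at the aromatic carbon: compound 1 to compound 3

The compounds below may be only part of what the source reports. "The series", "measured", "known", "first", "only" and "open" are said of these compounds alone.

Two measured compounds set the frame. In an assay on isolated protein for inhibition of DNA topoisomerase 1 (Homo sapiens), with a stated time of 15 min (a higher number here means a weaker inhibitor, a lower number a stronger inhibitor), compound 1 `COc1c(N2CC[C@@H](N)C2)c(F)cc2c(=O)c(C(=O)O)cn(Cc3ccc(-c4ccccc4)cc3)c12` gives 92200 nM, and compound 2 `O=C(O)c1cn(Cc2ccc(-n3cccn3)cc2)c2cc(N3CC4CNCC4C3)c(F)cc2c1=O` gives 173000 nM in this assay. The two numbers lie within the usual scatter of each other, so compound 1 cannot be set apart from compound 2 on these data; both sit at the weak end of what this assay reports.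

Compound 3 `CNCCCCNc1c(F)cc2c(=O)c(C(=O)O)cn(Cc3ccc(-c4ccccc4)cc3)c2c1OC` is not yet measured. It differs from compound 1 in one place: (4-(methylamino)butyl)amino in place of 3-aminopyrrolidin-1-yl on an aromatic carbon. Among the measured compounds shown here, no step between two measured compounds is available to say how this assay responds to such a change, so the expectation rests on the single value of compound 1 alone.

Nothing in the two measured compounds points in either direction; the expected step from compound 1 to compound 3 in this assay is a 1.2-fold higher number from compound 1 to compound 3 (0.08 log units; within the scatter), none beyond the scatter. Compound 3 is therefore estimated at 110000 nM in this assay, with a range from 35000 nM to 350000 nM.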

Compound 3, half-maximal inhibitory concentration: > 200000 nM
Compound 3: only a limit was reported; the forecaster's own chance of this, stated with the estimate: 25%; middle value at least 1.8-fold (0.25 log units) away from the limit.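

In this assay, (4-(methylamino)butyl)amino in place of 3-aminopyrrolidin-1-yl on this aromatic carbon, ortho to the fluoro and methoxy groups, gives an at least 2.1-fold higher number from compound 1 to compound 3 (0.33 log units; beyond the scatter). Among the compounds shown here, this is the first readable step, and it shows that the number responds to the group at this position: the open chain with no ring does not match the 3-aminopyrrolidin-1-yl group of compound 1. Compound 3 gives > 200000 nM, which is a limit of the assay and not a number, so the step fixes only a direction and a minimum size, and how far the change really reaches remains unknown: the limit of > 200000 nM in this assay, at which 1 of the 3 values shown sits.

A single pair cannot separate the loss of the ring from the chain length or from the methylamino end, and a shorter chain ending in a primary amine, or a piperazine ring, on the same carbon would bear on that. Also open, going by these compounds, is whether any amine at this position can bring the number well below that of compound 1, which still sits at the weak end of this assay.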